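A few compounds are considered here, and "the series" means these few. Any claim that something is new, unique, unknown or untested is made for them only; others in the source may bear on it.

Measured so far:
compound 1, `Cc1cn(C2CCN(Cc3cc(Oc4cc(Cl)cc(Cl)c4)ccn3)CC2)c(=O)[nH]c1=O`: "not determined" (no result reported)
compound 2, `Cc1cn(C2CCN(Cc3cccc(Oc4ccncc4)c3)CC2)c(=O)[nH]c1=O`: "not determined" (no result reported)
compound 3, `Cc1cn(C2CCN(Cc3ccnc(Oc4ccccc4)c3)CC2)c(=O)[nH]c1=O`: > 64000 nM

All three share one core and were examined in an ADME assay on MRC5 cells (Homo sapiens) for cytotoxicity, read by fluorescence and resazurin assay, with a stated time of 3 days; on this read-out lower numbers stand for stronger inhibition and higher numbers for weaker inhibition. Compound 3 gives only a limit of the assay, > 64000 nM, not a number. Compound 2 stands without a number of its own in this assay; of the three entries shown, one sits at the limit of > 64000 nM in this assay, at which 1 of the 3 values shown sits, and the other two hold no result. Compound 4, `COc1cccc(Oc2cccc(CN3CCC(n4cc(C)c(=O)[nH]c4=O)CC3)c2)c1`, differs from compound 2 by 3-methoxyphenyl in place of pyridin-4-yl on an oxygen on an aromatic ring. Among the compounds with values here, no step between measured compounds exists, so in this assay the expected change from compound 2 to compound 4 is none beyond the scatter. Within the data shown here, compound 4 is therefore expected near 64000 nM, within 20000 nM to 200000 nM, because the one value measured sits at the limit of > 64000 nM in this assay, at which 1 of the 3 values shown sits.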

Compound 4, half-maximal inhibitory concentration: 25300 nM
The estimate for compound 4 lay 2.5-fold (0.40 log units) above the measured number; measured number inside the range.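

In this assay, no step can be read from compound 2 to compound 4: compound 2 has no number to set against compound 4 at 25300 nM. From the compounds shown here alone, the effect of 3-methoxyphenyl in place of pyridin-4-yl stays open.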